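This account rests on a few compounds, and the source may have more. Where it says the series, first, only, none or still open, it means among the compounds named here.

Compound 1, `CCCCCc1ccc(-c2cc3cn([C@H]4C[C@H](O)[C@@H](COC(=O)[C@@H](NC(=O)[C@@H]5CCCN5C(=O)[C@@H](N)C(C)C)C(C)C)O4)c(=O)nc3o2)cc1`, carries an isopropyl on a saturated chain carbon bound to an amide-type nitrogen and a carbonyl carbon. In an ADME assay on HEL cells (Homo sapiens) for cytotoxicity (a higher number here means that more compound is tolerated, a lower number that less compound is tolerated), compound 1 gives > 2000 nM, which is a limit of the assay and not a number. Two close relatives were also tested. Compound 2, `CCCCCc1ccc(-c2cc3cn([C@H]4C[C@H](O)[C@@H](COC(=O)[C@H](CC(C)C)NC(=O)[C@@H]5CCCN5C(=O)[C@@H](N)C(C)C)O4)c(=O)nc3o2)cc1`, has isobutyl in that place, and in this assay compound 2 gives > 500 nM, again a limit. Compound 3, `CCCCCc1ccc(-c2cc3cn([C@H]4C[C@H](O)[C@@H](COC(=O)[C@H](C)NC(=O)[C@@H]5CCCN5C(=O)[C@@H](N)C(C)C)O4)c(=O)nc3o2)cc1`, has methyl there, and in this assay compound 3 gives > 500 nM, also a limit. The step from compound 1 to compound 2 is therefore a step that the two limits leave unreadable from compound 1 to compound 2, the step from compound 1 to compound 3 is a step that the two limits leave unreadable from compound 1 to compound 3, and the step from compound 2 to compound 3 is a step that the two limits leave unreadable from compound 2 to compound 3; none of them yields a readable size, since one value sits at the limit of > 2000 nM in this assay, at which 1 of the 3 values shown sits, and two sit at the limit of > 500 nM in this assay, at which 2 of the 3 values shown sit.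

Compound 4, `CCCCCc1ccc(-c2cc3cn([C@H]4C[C@H](O)[C@@H](COC(=O)[C@@H](NC(=O)[C@@H]5CCCN5C(=O)[C@@H](N)CCCCN)C(C)C)O4)c(=O)nc3o2)cc1`, differs from compound 1 at a different place: 4-aminobutyl in place of isopropyl on a saturated chain carbon bound to an amine nitrogen and a carbonyl carbon. Among the compounds with values here, no measured step touches that position, so the three relatives give no direction for it. Compound 4 is therefore expected to behave like compound 1 in this assay, with a step that the limit leaves unreadable from compound 1 to compound 4 that is estimated to stay within the scatter. The expected value for compound 4 is 3000 nM, in a range from 1200 nM to 8000 nM.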

Compound 4, minimum cytotoxic concentration: > 5000 nM
Compound 4 ended at the assay's limit; the forecaster's own chance of this, stated with the estimate: 80%; middle value at least 1.6-fold (0.22 log units) from the limit.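

In this assay compound 4 gives > 5000 nM, which is a limit of the assay and not a number. Compound 1 also stands at a limit, so no size can be read for the step between compound 1 and compound 4. The compounds shown leave open whether 4-aminobutyl in place of isopropyl changes how much compound is tolerated.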